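Swapping the Pyrrolidine of Compound 3 for an Aminoethylpiperidine

This account rests on a few compounds, and the source may have more. Where it says the series, first, only, none or still open, it means among the compounds named here.

Among the three measured compounds, compound 3 `Cc1cc(N2CCCC2)nc2ccc(NC(=O)c3ccc(Cl)c(Cl)c3)cc12` gives the highest number: in a functional assay on MCF7 cells (Homo sapiens) for antiproliferative activity, read by MTT assay, with a stated time of 72 h (a lower number here means a stronger inhibitor, a higher number a weaker inhibitor), compound 3 gives 26300 nM. Compound 1 `CCN1CCN(c2cc(C)c3cc(NC(=O)c4ccccc4)ccc3n2)CC1` gives 14200 nM, which lies within the scatter of compound 3, while compound 2 `CCN1CCN(c2cc(C)c3cc(NC(=O)c4ccc(Br)cc4)ccc3n2)CC1` gives 5940 nM, a gap beyond the scatter. Among the measured compounds shown here, the only measured step, a 2.4-fold lower number from compound 1 to compound 2 (0.38 log units; beyond the scatter), concerns the aromatic ring of the amide and not the position changed here. Compound 4 `Cc1cc(NCCN2CCCCC2)nc2ccc(NC(=O)c3ccc(Cl)c(Cl)c3)cc12` differs from compound 3 in one place: (2-(piperidin-1-yl)ethyl)amino in place of pyrrolidin-1-yl on an aromatic carbon. For the measured compounds named here, no measured step bears on this change, so no step beyond the scatter is expected in either direction. Compound 4 is therefore expected to give about 20000 nM, within a range of 6000 nM to 70000 nM, an expected step of a 1.3-fold lower number from compound 3 to compound 4 (0.12 log units; within the scatter).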

Compound 4, half-maximal inhibitory concentration: 1190 nM
Compound 4: the middle estimate sits 17-fold (1.23 log units) above what was measured, outside the stated range (below it).
By their numbers in this assay, from the lowest: compound 4; then compound 2; then compounds 1 and 3 (each within the scatter of the next).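

At this position, on the aromatic carbon next to the ring nitrogen, the group strongly affects the result. In this assay, (2-(piperidin-1-yl)ethyl)amino in place of pyrrolidin-1-yl gives a 22-fold lower number from compound 3 to compound 4 (1.34 log units; beyond the scatter), and the entering group differs in its chain, its ring and its hydrogen-bond donor, so this single step cannot separate their contributions. Nothing available explains the step. Going by these compounds, it remains open whether a longer propyl chain between the two nitrogens would keep this step. On these data alone, it is also open whether a terminal dimethylamino group or morpholine could replace the piperidine without losing it.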